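The compounds below may be only part of what the source reports. "The series", "measured", "known", "first", "only" and "open" are said of these compounds alone.

For the measured compounds named here, in a functional assay for antagonist activity at C-X-C chemokine receptor type 3 (Homo sapiens) (on this read-out higher numbers stand for weaker inhibition and lower numbers for stronger inhibition), compound 2 `C[C@H]1CN(c2ncc(NC(=O)C3CC3)cc2Cl)CCN1C1CCN(Cc2ccc(Cl)cc2)CC1` gives 20 nM, the higher of the two numbers so far. Going by the values given here, compound 1 `C[C@H]1CN(c2ncc(C(=O)NCc3ccc(F)c(F)c3)cc2Cl)CCN1C1CCN(Cc2ccc(Cl)cc2)CC1` gives 6 nM in this assay, and the single measured step, a 3.3-fold higher number from compound 1 to compound 2 (0.52 log units; beyond the scatter), separates the pair. Compound 3 `CC(C)NC(=O)c1cnc(N2CCN(C3CCN(Cc4ccc(Cl)cc4)CC3)[C@@H](C)C2)c(Cl)c1` differs from compound 2 in one place: isopropylcarbamoyl in place of (cyclopropylcarbonyl)amino on an aromatic carbon. This partly retraces the measured step, since compound 3 carries a carbamoyl group as compound 1 does, though with an isopropyl group where compound 1 has the (3,4-difluorobenzyl) group. Because a 3.3-fold higher number from compound 1 to compound 2 (0.52 log units; beyond the scatter) was the cost of moving away from the carbamoyl arrangement, a partial return is expected to recover some of it, a modest step downward in this assay, short of the number for compound 1. Compound 3 is therefore estimated at 12 nM in this assay, with a range from 4 nM to 40 nM, meaning an expected step of a 1.7-fold lower number from compound 2 to compound 3 (0.22 log units; within the scatter).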

Compound 3, half-maximal inhibitory concentration: 5 nM
Estimate against measurement, compound 3: 2.4-fold (0.38 log units) above; the range from low to high includes it.
By their numbers in this assay, from the lowest: compounds 3 and 1 (each within the scatter of the next); then compound 2.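

Swapping (cyclopropylcarbonyl)amino for isopropylcarbamoyl leaves the counts of heavy atoms, hydrogen-bond donors and hydrogen-bond acceptors unchanged, yet this assay shows a 4.0-fold lower number from compound 2 to compound 3 (0.60 log units; beyond the scatter), so at this place on the ring, para to a large group, the number responds to more than those counts. The isopropyl group on the amide-type nitrogen also matches the larger 3,4-difluorobenzyl group, with a 1.2-fold lower number from compound 1 to compound 3 (0.08 log units; within the scatter), so the benzyl group is not required for a number in this range. No measurement offered here accounts for either result.

The step from compound 2 to compound 3 both reverses the amide and removes the three-membered ring, and the two changes cannot be separated here. As far as these compounds go, how a cyclopropylcarbamoyl group, an unsubstituted carboxamide or a carboxylic acid would read at this position remains open.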